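Clearance of compound 4 after one stereocentre changes

The source may hold more compounds than are shown below. What is called first, only, known or untested is meant among the compounds shown, and "the series" means these compounds.

compound 1 `OC(c1ncccn1)C1(c2ccc(OC(F)(F)F)cc2)CCC1`: 100 mL/min/kg
compound 2 `OC(c1cc(F)ccn1)C1(c2ccc(Cl)c(Cl)c2)CCC1`: 533 mL/min/kg
compound 3 `O[C@H](c1ccccn1)[C@]1(c2ccc(Cl)c(Cl)c2)CCO1`: 66.7 mL/min/kg

All three numbers come from an ADME assay on liver for metabolic stability, with Liver microsome (Homo sapiens) as the target, read by LC-MS, using microsomes, with a stated time of 5 h (on this read-out higher numbers stand for fast clearance and lower numbers for slow clearance), and no two of these compounds differ in only one place, so no single structural change can be read from them. Compound 3 gives 66.7 mL/min/kg and stands within the usual scatter of compound 1 at 100 mL/min/kg in this read-out. Among the measured compounds shown here, compound 2 at 533 mL/min/kg stands beyond the scatter from compound 3 and marks the far end of the numbers so far.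

Compound 4 `O[C@H](c1ccccn1)[C@@]1(c2ccc(Cl)c(Cl)c2)CCO1` is now to be measured in this assay as the counterpart of compound 3. The change is the two compounds have the same atoms and bonds and differ only in configuration as drawn: 1 of 2 stereo elements differ; a stereocentre at a saturated ring carbon is drawn R in compound 3 and S in compound 4 and nothing leaves or enters: a stereocentre at a saturated ring carbon is drawn R in compound 3 and S in compound 4. For the measured compounds named here, the data hold no measured pair that shows what such a change does, so the expectation starts from compound 3 at 66.7 mL/min/kg and allows for a move either way. The expected change, a 1.2-fold higher number from compound 3 to compound 4 (0.08 log units; within the scatter), is a small rise and none beyond the scatter. For compound 4 the estimated clearance is 80 mL/min/kg with an expected range from 35 mL/min/kg to 190 mL/min/kg and the measurement will settle it.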

Compound 4, clearance: 217 mL/min/kg
Compound 4: middle estimate off by 2.7-fold (0.43 log units), on the low side; measured number above the stated range.
By their numbers in this assay, from the lowest: compounds 3 and 1 (each within the scatter of the next); then compound 4; then compound 2.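

In this assay, this saturated ring carbon proves to be a place where configuration alone moves the number: changing the stereocentre there from R to S gives a 3.3-fold higher number from compound 3 to compound 4 (0.51 log units; beyond the scatter). Among the compounds shown here, the earlier compounds could not show this, since no two of them differed in only one place, so this is the first step in the set that can be read as a single change. Nothing but this stereocentre can account for the step, because no other difference exists within the pair: the fact that compounds 3 and 4 differ only in the configuration as drawn.

The compounds shown leave open what the second stereo element, which is the same in both compounds, does to clearance, and by what route the change at the ring carbon raises the number. They also leave open whether the same change would give a step of similar size on a compound carrying a different group, such as an amine or a carboxylic acid, in place of the hydroxyl.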